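A few compounds are considered here, and "the series" means these few. Any claim that something is new, unique, unknown or untested is made for them only; others in the source may bear on it.

Three compounds of a shared core, each carrying a carbonyl joined through a double-bonded chain carbon to a second ring, have been tested in a functional assay on 786-0 cells (Homo sapiens) for cytotoxicity, read by sulforhodamine B assay, with a stated time of 48 h, tested at 1 uM; on this read-out higher numbers stand for a weaker effect at the one concentration tested and lower numbers for a stronger effect. Compound 1 `COc1ccc(-c2cc(/C=C/C(=O)c3ccc(OC)c(OC)c3)[nH]n2)cc1` gives 86%. Compound 2 `COc1cc(-c2cc(/C=C/C(=O)c3ccc(Cl)c(Cl)c3)[nH]n2)cc(OC)c1OC` gives 91%. Compound 3 `COc1cc(C(=O)/C=C/c2cc(-c3cc(OC)c(OC)c(OC)c3)n[nH]2)cc(OC)c1OC` gives 80%. Among these three numbers compound 2 stands highest: its nearest neighbour is compound 1, whose number lies within the usual scatter of it, and its furthest is compound 3, whose number lies beyond that scatter.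

Compound 4 `COc1cc(-c2cc(/C=C/C(=O)c3ccc(F)c(F)c3)[nH]n2)cc(OC)c1OC` has not yet been measured. It is reached from compound 2 by one change, (3,4-difluorophenyl in place of 3,4-dichlorophenyl on a carbonyl carbon), so the ring on the carbonyl carbon keeps its size and its two substituent positions while the two chlorines give way to two fluorines. Among the compounds with values here, no pair of measured compounds differing in only one place is available to show how large such a swap is here, and the three measured numbers all sit in a fairly narrow band of weak effect at the one concentration used.

The step from compound 2 to compound 4 is therefore expected to be small, a number 3 percentage points lower from compound 2 to compound 4 (within the scatter), with no change beyond the scatter in either direction. Compound 4 is accordingly estimated to give 88% in this assay, most likely between 75% and 99%.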

Compound 4, a percentage reported as activity, at one concentration (the size of the read-out at that concentration, not a potency): 93%
The estimate for compound 4 lay 5 percentage points below the measured number; the measured number falls inside the stated range.
By their numbers in this assay, from the lowest: compounds 3, 1, 2 and 4 (each within the scatter of the next, the first and the last beyond it).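

In this assay, placing 3,4-difluorophenyl in place of 3,4-dichlorophenyl on a carbonyl carbon gives a number 2 percentage points higher from compound 2 to compound 4 (within the scatter). Within the data shown here, this is the first pair that differs in only one place, and it offers a direct look at this position: at the single concentration tested, the two fluorines and the two chlorines cannot be told apart. No measurement is available that would explain this result.

As far as these compounds go, it remains open whether a very different group on this ring, such as an amine or a carboxylic acid in place of the two halogens, would move the number beyond the usual scatter. Among these compounds, it is also unknown whether the same swap would behave alike with the other ring of compound 2 changed, and a reading at one concentration gives no potency for either compound.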